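The source may hold more compounds than are shown below. What is called first, only, known or untested is meant among the compounds shown, and "the series" means these compounds.

Compound 1 `COc1cc(OC)c(/C=C/C(=O)/C=C/c2cc3ccccc3nc2Cl)c(OC)c1`: > 10000 nM
Compound 2 `COc1cc(OC)c(/C=C/C(=O)/C=C/c2cc3ccccc3nc2Oc2ccccc2)c(OC)c1`: > 10000 nM
Compound 3 `COc1ccc(OC)c(/C=C/C(=O)/C=C/c2cc3ccccc3nc2Oc2cccc(Cl)c2)c1`: > 10000 nM

These three results come from a functional assay on DU-145 cells (Homo sapiens) for cytotoxicity, read by MTT assay, with a stated time of 48 h (a lower number here means a stronger inhibitor, a higher number a weaker inhibitor), and each is a limit rather than a number, as the limit of > 10000 nM in this assay, at which 3 of the 3 values shown sit, records. Compound 3 therefore has no exact position in the series, and its result can only be read as the limit > 10000 nM.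

Compound 4 `COc1cc(OC)c(/C=C/C(=O)/C=C/c2cc3ccccc3nc2Oc2cccc(Cl)c2)c(OC)c1` has 2,4,6-trimethoxyphenyl in place of 2,5-dimethoxyphenyl, on a double-bonded chain carbon bound to a double-bonded chain carbon: 2,4,6-trimethoxyphenyl in place of 2,5-dimethoxyphenyl on a double-bonded chain carbon bound to a double-bonded chain carbon.

Among the compounds with values here, no measured step covers this exchange. Within the data shown here, the one step available, a step that the two limits leave unreadable from compound 1 to compound 2, gives no size to carry over. The entering group is already present in compound 2, whose result is the limit > 10000 nM. It is also present in compound 1, whose result is the limit > 10000 nM.

No step beyond the scatter is therefore expected in this assay, and no direction can be favoured. The expected change is a step that the limit leaves unreadable from compound 3 to compound 4. For compound 4 the estimate is 12000 nM, with an expected range of 4000 nM to 30000 nM.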

Compound 4, half-maximal inhibitory concentration: > 10000 nM
Compound 4: no number, only a limit (the forecaster's own chance of this, stated with the estimate: 75%); the middle value lies beyond the limit too.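

In this assay, compound 4 gives only a limit, as do compounds 1, 2 and 3, so no step among these four compounds can be read: the limit of > 10000 nM in this assay, at which 4 of the 4 values shown sit.

The compounds shown leave open how far each lies beyond that limit, and whether any of these exchanges shifts the result at all.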